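The source may hold more compounds than are shown below. What is called first, only, known or untested is meant among the compounds shown, and "the series" means these compounds.

Measured so far in a functional assay for inhibition of sodium/hydrogen exchanger (Oryctolagus cuniculus); on this read-out higher numbers stand for weaker inhibition and lower numbers for stronger inhibition:

- compound 1, `CCc1cc(Br)c(S(C)(=O)=O)cc1C(=O)N=C(N)N` — 41 nM
- compound 2, `CS(=O)(=O)c1cc(C(=O)N=C(N)N)c(Cl)cc1Cl` — 140 nM
- compound 3, `CCC(C)c1cc(C)c(C(=O)N=C(N)N)cc1S(C)(=O)=O` — 8 nM

Compound 3 holds the lowest number of the three, and both its gaps lie beyond the scatter: compound 1 sits higher and compound 2 higher still, so on these three numbers compound 3 is the strongest inhibitor of the set. For the measured compounds named here, no two measured compounds differ in a single place, so no measured step exists to lean on for the next change.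

Compound 4, `Cc1cc(SC(C)C)c(S(C)(=O)=O)cc1C(=O)N=C(N)N`, is the next compound to be measured. Relative to compound 3 it carries isopropylsulfanyl in place of sec-butyl on an aromatic carbon. The group leaving and the group entering match in heavy-atom count and both lack rings; the entering group brings one hydrogen-bond acceptor and a sulfur in place of a carbon. Going by the values given here, with no measured step for this kind of exchange, the expectation rests on the likeness of the two groups in size and shape: a small step from compound 3 to compound 4 in this assay, most likely within the scatter or a little toward a higher number, is expected, written as a 1.5-fold higher number from compound 3 to compound 4 (0.18 log units; within the scatter). For compound 4 the estimate in this assay is 12 nM, with a range from 4 nM to 40 nM.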

Compound 4, half-maximal inhibitory concentration: 12 nM
Estimate against measurement, compound 4: no gap at the digits printed, and the stated range covers the measured number.
By their numbers in this assay, from the lowest: compounds 3 and 4 (each within the scatter of the next); then compound 1; then compound 2.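

In this assay, replacing sec-butyl with isopropylsulfanyl on the aromatic carbon ortho to a methylsulfonyl group gives a 1.5-fold higher number from compound 3 to compound 4 (0.18 log units; within the scatter), the only step shown between compounds that differ in one place. At this position, with the heavy-atom count unchanged, a sulfur in place of a carbon and the one hydrogen-bond acceptor that enters with it therefore leave the number within the scatter. No measurement shown bears on why the two groups read alike.

The compounds shown leave open whether a group of another kind at this position, such as an amine, a carboxylic acid or a longer alkylsulfanyl chain, would also stay within the scatter. They also leave open how isopropoxy, with oxygen in place of the sulfur, would read there.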